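Bromo to Methyl on the Phenoxy Ring

This account rests on a few compounds, and the source may have more. Where it says the series, first, only, none or still open, it means among the compounds named here.

Measured so far:
compound 1, `Cc1ccc(Oc2c(/C=N\OCc3c(Cl)c(-c4ccc(F)cc4)nn3C)c(C)nn2C)cc1`, 5230 nM
compound 2, `Cc1nn(C)c(Oc2ccc(Br)cc2)c1/C=N\OCc1c(Cl)c(-c2ccc(Cl)cc2)nn1C`, 7130 nM

Compound 2 holds the higher of the two numbers in a functional assay on SMMC-7721 cells (Homo sapiens) for antiproliferative activity, read by MTT assay, with a stated time of 72 h (a lower number here means a stronger inhibitor, a higher number a weaker inhibitor), yet compound 1 with its value sits within the scatter of it, so the two cannot be ordered. Compound 3, `Cc1ccc(Oc2c(/C=N\OCc3c(Cl)c(-c4ccc(Cl)cc4)nn3C)c(C)nn2C)cc1`, has not been measured. It follows from compound 2 by a single change: methyl in place of bromo on an aromatic carbon. Among the measured compounds shown here, no measured pair shows this change, so its effect is not known from the data. Compound 3 is also close to compound 1, which gives 5230 nM in this assay, differing from it only on the other aromatic ring. Both neighbours sit in a narrow band, so the author expects compound 3 to land in that band as well, with a step of a 1.3-fold lower number from compound 2 to compound 3 (0.11 log units; within the scatter) that stays within the scatter. The estimate for compound 3 in this assay is 5500 nM, between 2500 nM and 12000 nM.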

Compound 3, half-maximal inhibitory concentration: 5840 nM
Compound 3: the middle estimate sits 1.1-fold (0.03 log units) below what was measured; the measured number falls inside the stated range.
By their numbers in this assay, from the lowest: compounds 1, 3 and 2 (each within the scatter of the next).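

In this assay, methyl in place of bromo on the phenoxy ring, para to a large group, gives a 1.2-fold lower number from compound 2 to compound 3 (0.09 log units; within the scatter), so this assay does not tell 4-bromophenoxy from 4-methylphenoxy in this series. Chloro in place of fluoro on an aromatic carbon of the other ring gives a 1.1-fold higher number from compound 1 to compound 3 (0.05 log units; within the scatter), which means that neither single change moves the result beyond the scatter. Nothing at hand explains either step.

The compounds shown carry only bromo or methyl at the first place and only fluoro or chloro at the second, so it remains open what an amine, a carboxylic acid or a longer chain would do at either one. From the compounds shown here alone, it also remains open whether any change at these places can move the result beyond the scatter.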